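The compounds below may be only part of what the source reports. "The series", "measured", "known", "first", "only" and "open" are said of these compounds alone.

Compound 1 `Cc1cc(C)c2cccc(OCc3c(Cl)ccc(S(=O)(=O)NC4(C(=O)N5CCN(C(=O)[C@@H](N)CCCCN)CC5)CCCC4)c3Cl)c2n1` and compound 2 `Cc1cc(C)c2cccc(OCc3c(Cl)ccc(S(=O)(=O)NC4(C(=O)N5CCN(C(=O)CCCCC[N+](C)(C)C)CC5)CCCC4)c3Cl)c2n1` share the same core and differ only in the group attached to a carbonyl carbon. In an assay on isolated protein for binding affinity to B1 bradykinin receptor (Homo sapiens) (a higher number here means a weaker inhibitor, a lower number a stronger inhibitor), compound 1 gives only a limit, < 10000 nM. In this assay compound 2 likewise gives only a limit, < 10000 nM. The step that the two limits leave unreadable from compound 1 to compound 2 thus has no readable size, since both values sit at the same limit (the limit of < 10000 nM in this assay, at which 2 of the 2 values shown sit). Compound 3 `Cc1cc(C)c2cccc(OCc3c(Cl)ccc(S(=O)(=O)NC4(C(=O)N5CCN(C(=O)C[C@H](CCCN)[N+](C)(C)C)CC5)CCCC4)c3Cl)c2n1` is reached from compound 2 by a single change: a group of 9 heavy atoms (7 carbon, 2 nitrogen; no ring) in place of a group of 8 heavy atoms (7 carbon, 1 nitrogen; no ring), on a saturated chain carbon bound to a carbonyl carbon. Among the compounds with values here, the only measured step, from compound 1 to compound 2, concerns a different place and yields no size, so it gives no ground to expect a shift in this assay beyond the scatter in either direction. Compound 3 is therefore expected to give a value near 2000 nM, within 200 nM to 10000 nM, and quite possibly again only a limit. The expected step is estimated as a step that the limit leaves unreadable from compound 2 to compound 3.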

Compound 3, inhibition constant: < 10000 nM
Compound 3 gave a limit, no number; the forecaster's own chance of this, stated with the estimate: 70%; the middle value is on the limit's open side.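

Within the data shown here, compound 1, compound 2 and compound 3 each give only a limit in this assay, so no step among them can be read: the limit of < 10000 nM in this assay, at which 3 of the 3 values shown sit. The compounds shown leave open how strongly each one actually binds and whether these changes in the side chain alter that at all.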